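The compounds below may be only part of what the source reports. "The series", "measured", "known", "first", "only" and "open" are said of these compounds alone.

Measured in a functional assay on A549 cells (Homo sapiens) for cytotoxicity, read by MTT assay, with a stated time of 48 h; a lower number here means a stronger inhibitor, a higher number a weaker inhibitor:
- compound 1 `C=C1CCC[C@]2(C)CCC(c3cn(-c4cccc([N+](=O)[O-])c4)nn3)=CC[C@@]12C`: 24700 nM
- compound 2 `C=C1CCC[C@]2(C)CCC(c3cn(-c4ccc(I)cc4)nn3)=CC[C@@]12C`: 137000 nM

Compound 2 has the higher of the two numbers, so it is the weaker inhibitor in this assay. Compound 3 `C=C1CCC[C@]2(C)CCC(c3cn(-c4ccccc4C(C)=O)nn3)=CC[C@@]12C` keeps the shared core and has 2-acetylphenyl in place of 4-iodophenyl on an aromatic nitrogen. Within the data shown here, only one measured step swaps a group at that place, a 5.5-fold higher number from compound 1 to compound 2 (0.74 log units; beyond the scatter), and it is modest. With just this step as a guide, a step of similar size towards a lower number is expected, estimated as a 2.7-fold lower number from compound 2 to compound 3 (0.44 log units; beyond the scatter). For compound 3 the expected value is 50000 nM, with an estimated range of 15000 nM to 150000 nM.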

Compound 3, half-maximal inhibitory concentration: 37700 nM
Compound 3: the middle estimate sits 1.3-fold (0.12 log units) above what was measured; the range from low to high includes it.
By their numbers in this assay, from the lowest: compounds 1 and 3 (each within the scatter of the next); then compound 2.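

In this assay, replacing 4-iodophenyl with 2-acetylphenyl on the aromatic nitrogen gives a 3.6-fold lower number from compound 2 to compound 3 (0.56 log units; beyond the scatter), so the 4-iodophenyl group is the one that stands apart among these three. Replacing 3-nitrophenyl with 2-acetylphenyl gives a 1.5-fold higher number from compound 1 to compound 3 (0.18 log units; within the scatter), so these two different aryl groups cannot be told apart in this assay. No measurement here explains the difference from 4-iodophenyl. Open, as far as these compounds go, is how a phenyl ring carrying an amine or a carboxylic acid would compare. Also open, from the compounds shown here alone, is whether a longer alkyl chain could replace the ring at this nitrogen.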